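Changing only the drawn configuration at one stereocentre

This account rests on a few compounds, and the source may have more. Where it says the series, first, only, none or still open, it means among the compounds named here.

Three compounds sharing one core were tested in an ADME assay on the whole organism with Oryza sativa as the target, tested at 10 uM; a lower number here means a stronger effect, a higher number a weaker effect of the compound at the concentration tested. Compound 1 `C[C@H](NC(=O)Nc1ccccc1Cl)c1ccccc1` gives 106%. Compound 2 `C[C@H](NC(=O)Nc1cccc(Cl)c1)c1ccccc1` gives 103% in this assay. Compound 3 `C[C@@H](NC(=O)Nc1cccc(Cl)c1Cl)c1ccccc1` gives 99% in this assay. Compound 3 stands at the lowest of the three numbers, yet its gap to compound 2 and its gap to compound 1 both lie within the usual scatter of repeated measurements, so none of the three is set apart from the others by this read-out.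

Compound 4 `C[C@H](NC(=O)Nc1cccc(Cl)c1Cl)c1ccccc1` has not yet been measured. Its relation to compound 3 is this: the two compounds have the same atoms and bonds and differ only in configuration as drawn: 1 of 1 stereo elements differ; a stereocentre at a saturated chain carbon is drawn R in compound 3 and S in compound 4. No group leaves and none enters. Among the measured compounds shown here, no pair among the measured compounds differs in a single place, so there is no earlier step to lean on, and the expectation rests on the structural change alone. The step expected is a number 1 percentage points higher from compound 3 to compound 4 (within the scatter), which is nothing beyond the scatter. For compound 4 the expected value is 100%, with a range from 88% to 112%.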

Compound 4, a percentage reported as activity, at one concentration (the size of the read-out at that concentration, not a potency): 101%
Compound 4: middle estimate off by 1 percentage points, on the low side; the range from low to high includes it.
By their numbers in this assay, from the lowest: compounds 3, 4, 2 and 1 (each within the scatter of the next).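

In this assay, reversing the drawn configuration at the saturated chain carbon gives a number 2 percentage points higher from compound 3 to compound 4 (within the scatter), so at the concentration tested this stereocentre shows no effect that can be told from the scatter. Chloro in place of hydrogen on an aromatic carbon gives a number 2 percentage points lower from compound 2 to compound 4 (within the scatter) and a number 5 percentage points lower from compound 1 to compound 4 (within the scatter), so adding a chloro to either singly chlorinated compound also leaves the number within the scatter. The first of these steps is the only one here that tests the stereocentre alone, because nothing else changes: the fact that compounds 3 and 4 differ only in the configuration as drawn

All the compounds shown carry only chloro groups on the aromatic ring, so it stays open whether a methoxy group, an amine or a carboxylic acid there would move the number beyond the scatter. From the compounds shown here alone, it is equally open whether a longer chain at the stereocentre would do so, or would make the drawn configuration matter.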